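Aryl replacement on the shared core: compound 3

A few compounds are considered here, and "the series" means these few. Any claim that something is new, unique, unknown or untested is made for them only; others in the source may bear on it.

Measured so far:
compound 1, `Cc1ccc(Nc2cc(NC(=O)Nc3c(Cl)cccc3Cl)ncn2)cc1F`, in a functional assay on NCI-H520 cells (Homo sapiens) for inhibition, read by MTT assay, with a stated time of 48 h, tested at 10 uM (on this read-out lower numbers stand for less inhibition and higher numbers for more inhibition at the one concentration tested (going by the name of the read-out)), gives 33.5%.
compound 2, `COc1ccc(Nc2cc(NC(=O)Nc3c(Cl)cccc3Cl)ncn2)cc1C`, in this assay gives 29.1%.

Within the data shown here, compound 2 carries the smaller of the two numbers, but the only measured step, a number 4.4 percentage points lower from compound 1 to compound 2 (within the scatter), is within the scatter, so the two compounds cannot be separated on these data. Compound 3, `O=C(Nc1cc(Nc2ccc(F)c(Cl)c2)ncn1)Nc1c(Cl)cccc1Cl`, differs from compound 2 by 3-chloro-4-fluorophenyl in place of 4-methoxy-3-methylphenyl on a nitrogen on an aromatic ring. Among the measured compounds shown here, the one measured step exchanged the aryl group on the same nitrogen and stayed within the scatter; no compound with a 3-chloro-4-fluorophenyl group has been measured, so the expectation rests on that single step alone. Given a number 4.4 percentage points lower from compound 1 to compound 2 (within the scatter), which lay within the scatter, the step expected for compound 3 is a number 1.9 percentage points higher from compound 2 to compound 3 (within the scatter), that is, no movement beyond the scatter. Compound 3 is therefore estimated to give about 31% in this assay, expected to fall between 15% and 50%.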

Compound 3, a percentage reported as inhibition, at one concentration (the size of the read-out at that concentration, not a potency): 39.5%
Estimate against measurement, compound 3: 8.5 percentage points below; measured number inside the range.
By their numbers in this assay, from the lowest: compounds 2, 1 and 3 (each within the scatter of the next, the first and the last beyond it).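

In this assay, among these compounds, the exchange of 4-methoxy-3-methylphenyl for 3-chloro-4-fluorophenyl on a nitrogen on an aromatic ring gives a number 10.4 percentage points higher from compound 2 to compound 3 (beyond the scatter), the only step at this position among the three compounds to pass the scatter, so the aryl group on this nitrogen can shift the read-out, though modestly. The exchange of 3-fluoro-4-methylphenyl for the same 3-chloro-4-fluorophenyl gives a number 6 percentage points higher from compound 1 to compound 3 (within the scatter), which leaves compound 1 and compound 3 unseparated, so only the two ends of this short series, compound 2 and compound 3, are resolved from each other. No measurement at hand accounts for the step from 4-methoxy-3-methylphenyl to 3-chloro-4-fluorophenyl.

All three aryl groups here are substituted phenyl rings with a methyl, methoxy, fluorine or chlorine substituent, so the compounds shown leave open how the read-out would move with an aryl ring bearing an amine or a carboxylic acid on this nitrogen, or with a saturated ring in place of the phenyl. The read-out also stands at one concentration, and the compounds shown do not tell whether the modest step at this position would carry over to a potency measure or hold with a different group in place of the dichlorophenyl on the urea.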